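This account rests on a few compounds, and the source may have more. Where it says the series, first, only, none or still open, it means among the compounds named here.

Working notes on the series. Two compounds carry numbers in a functional assay on cells for antagonist activity at D(4) dopamine receptor (Homo sapiens), read by TR-FRET and cAMP accumulation, with a stated time of 30 min; a lower number here means a stronger inhibitor, a higher number a weaker inhibitor. Compound 1 `CCc1cccc(NC(=O)CN2CCN(c3ccccn3)CC2)c1` gives 1310 nM in this assay. Compound 2 `Cc1cccc(NC(=O)CN2CCN(c3ccc(Cl)cn3)CC2)c1` gives 4700 nM in this assay, the higher of the two numbers; the gap to compound 1 lies beyond the scatter, but the two structures differ in more than one place, so no single step can be read from it. Compound 3 `CCc1cccc(NC(=O)CN2CCN(c3ccc(Cl)cn3)CC2)c1` is compound 2 with methyl in place of hydrogen on a saturated chain carbon bound to an aromatic carbon. Within the data shown here, no measured pair isolates this change, so the step of a 1.6-fold lower number from compound 2 to compound 3 (0.19 log units; within the scatter) is expected to be small, if any. Compound 3 is estimated at 3000 nM, range 1000 nM to 9000 nM.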

Compound 3, half-maximal inhibitory concentration: 7060 nM
For compound 3 the middle estimate is 2.4-fold (0.37 log units) below the measured one; low and high end bracket the measured number.
By their numbers in this assay, from the lowest: compound 1; then compounds 2 and 3 (each within the scatter of the next).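

In this assay the change from 3-methylphenyl to 3-ethylphenyl, with the chloro group present, gives a 1.5-fold higher number from compound 2 to compound 3 (0.18 log units; within the scatter) and so leaves no readable effect at this saturated chain carbon bound to an aromatic carbon. Compound 3 also isolates chloro in place of hydrogen on an aromatic carbon, with a 5.4-fold higher number from compound 1 to compound 3 (0.73 log units; beyond the scatter) as a modest step. Nothing measured on these compounds accounts for either step.

Going by these compounds, whether a longer chain such as propyl, or an amine, at the ethyl position would move the number remains open. So does whether fluoro or methoxy in place of the chloro would give a step of similar size.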